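This account rests on a few compounds, and the source may have more. Where it says the series, first, only, none or still open, it means among the compounds named here.

Measured so far in a functional assay on BV-2 cells (Mus musculus), read by Griess assay, with a stated time of 24 h; on this read-out higher numbers stand for weaker inhibition and lower numbers for stronger inhibition:
- compound 1 `C=C(C)CC1COC2(C=CC(=O)C=C2)N(c2ccccc2)C1=O`: 450 nM
- compound 2 `O=C1C=CC2(C=C1)OCC(Cc1ccc(Cl)cc1)C(=O)N2c1ccccc1`: 540 nM
- compound 3 `O=C1C=CC2(C=C1)OCC(Cc1ccc([N+](=O)[O-])cc1)C(=O)N2c1ccccc1`: 430 nM

The three values cannot be told apart. Compound 3 at 430 nM is level with the other two, as shown by a 1.0-fold lower number from compound 1 to compound 3 (0.02 log units; within the scatter) and a 1.3-fold lower number from compound 2 to compound 3 (0.10 log units; within the scatter).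

Next is compound 4 `Cc1cc(C)cc(CC2COC3(C=CC(=O)C=C3)N(c3ccccc3)C2=O)c1`, which carries 3,5-dimethylphenyl in place of 4-nitrophenyl on a saturated chain carbon bound to a saturated ring carbon.

Among the measured compounds shown here, no measured compound carries 3,5-dimethylphenyl, so the expectation rests on how the same position has behaved so far. The closest evidence is a 1.3-fold lower number from compound 2 to compound 3 (0.10 log units; within the scatter), a swap of one aromatic substituent for another. Two wider swaps point the same way: a 1.2-fold higher number from compound 1 to compound 2 (0.08 log units; within the scatter) and a 1.0-fold lower number from compound 1 to compound 3 (0.02 log units; within the scatter), each replacing 1-methylethenyl with a substituted phenyl. For the measured compounds named here, none of these steps leaves the scatter, although the data cover only three groups at this position and none with two substituents on the phenyl.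

No step beyond the scatter is therefore expected in this assay, and the estimated step is a 1.1-fold higher number from compound 3 to compound 4 (0.03 log units; within the scatter). For compound 4 the expected value is 460 nM, with an estimated range from 230 nM to 900 nM.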

Compound 4, half-maximal inhibitory concentration: 1820 nM
Estimate against measurement, compound 4: 4.0-fold (0.60 log units) below; the whole stated range lies below it.
By their numbers in this assay, from the lowest: compounds 3, 1 and 2 (each within the scatter of the next); then compound 4.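

In this assay, among the compounds shown here, this position is no longer indifferent to the group it carries: 1-methylethenyl, 4-chlorophenyl and 4-nitrophenyl sat within the scatter of one another, whereas 3,5-dimethylphenyl gives the first steps beyond it (a 4.2-fold higher number from compound 3 to compound 4 (0.63 log units; beyond the scatter); a 3.4-fold higher number from compound 2 to compound 4 (0.53 log units; beyond the scatter); a 4.0-fold higher number from compound 1 to compound 4 (0.61 log units; beyond the scatter)). All three steps are modest and of similar reach, so the change is not tied to leaving the nitro group alone, as it appears against the chloro-substituted ring and the non-aromatic 1-methylethenyl as well. The series therefore shows that an aryl group at this saturated chain carbon does not guarantee the level of the earlier compounds, and no measurement available here bears on the reason for the shift.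

The compounds shown cannot separate the effect of having two substituents on the ring from that of methyl as the substituent, or from that of their placement. Unsubstituted phenyl, 4-methylphenyl, 3-methylphenyl and 3,5-dichlorophenyl at the same place would divide these readings, and 4-aminophenyl would extend the range of ring substituents.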